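Tert-butyl for 2-fluorophenyl: an expected clearance

A few compounds are considered here, and "the series" means these few. Any claim that something is new, unique, unknown or untested is made for them only; others in the source may bear on it.

compound 1 `COC(C)(C)[C@@H](O)C(=O)N1N=CC[C@H]1C(=O)NCc1cc(Cl)ccc1-n1cnnn1`: < 12 mL.min-1.g-1
compound 2 `O=C(NCc1cc(Cl)ccc1-n1cnnn1)[C@@H]1C[C@@H]2C[C@@H]2N1C(=O)[C@H](O)c1ccccc1F`: < 12 mL.min-1.g-1
compound 3 `O=C(NCc1cc(Cl)ccc1-n1cnnn1)[C@@H]1[C@H]2C[C@H]2CN1C(=O)[C@H](O)C1CCCCC1`: 110 mL.min-1.g-1

In an ADME assay on liver for metabolic stability, with Liver microsome (Homo sapiens) as the target, read by LC-MS, using microsomes (a higher number here means faster removal of the compound, a lower number slower removal), compound 2 gives < 12 mL.min-1.g-1, which is a limit of the assay and not a measured number. Compound 1 also rests at the limit of < 12 mL.min-1.g-1 in this assay, at which 2 of the 3 values shown sit, so compound 2 stands among the slower-cleared compounds shown. Going by the values given here, compound 3 gives 110 mL.min-1.g-1, a measured number, though it is built on a different core and no step between it and compound 2 has been measured.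

Compound 4 `CC(C)(C)[C@@H](O)C(=O)N1[C@H](C(=O)NCc2cc(Cl)ccc2-n2cnnn2)C[C@@H]2C[C@@H]21` differs from compound 2 by tert-butyl in place of 2-fluorophenyl on a saturated chain carbon bound to a carbonyl carbon and an oxygen on a saturated carbon. Among the compounds with values here, no pair of measured compounds shows the size of such a step. Since compound 2 sits at a limit, the step from compound 2 to compound 4 is expected to be small, an at least 1.5-fold higher number from compound 2 to compound 4 (0.17 log units; that floor lies within the scatter), likely within the scatter, with a fair chance that compound 4 also reports only a limit. Compound 1, which differs at the same place and rests at < 12 mL.min-1.g-1, supports a low expectation. Compound 4 is estimated at 18 mL.min-1.g-1, with a range from 7 mL.min-1.g-1 to 55 mL.min-1.g-1.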

Compound 4, intrinsic clearance in microsomes: 75 mL.min-1.g-1
The estimate for compound 4 lay 4.2-fold (0.62 log units) below the measured number, outside the stated range (above it).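

In this assay, the exchange of 2-fluorophenyl for tert-butyl on a saturated chain carbon bound to a carbonyl carbon and an oxygen on a saturated carbon gives an at least 6.2-fold higher number from compound 2 to compound 4 (0.79 log units; beyond the scatter), a step beyond the scatter. Going by these compounds alone, this is the first step between compounds that differ in one place, and it shows that clearance on the shared core depends on the group at this position. The full size of the step cannot be read, since compound 2 rests at a limit of the assay and not at a measured number: the limit of < 12 mL.min-1.g-1 in this assay, at which 2 of the 4 values shown sit.

This single step cannot separate the loss of the fluorine from the loss of the aromatic ring, and it leaves open how an unsubstituted phenyl or a pyridine ring would stand at this place. Nor do the compounds shown tell whether the same exchange would carry the same weight on the other cores.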